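Adding a Hydroxy to Compound 1

The source may hold more compounds than are shown below. What is called first, only, known or untested is meant among the compounds shown, and "the series" means these compounds.

Values in a functional assay on HCT-116 cells (Homo sapiens) for cytotoxicity, read by MTT assay, with a stated time of 72 h; a lower number here means a stronger inhibitor, a higher number a weaker inhibitor
Compound 1 `Cc1cc(/C=C/c2ccc(O)cc2)[nH]n1` gives 38800 nM
Compound 2 `COc1ccc(/C=C/c2cc(C)n[nH]2)cc1` gives 9400 nM

Of these two compounds, compound 1 has the higher number, 38800 nM, and is therefore the weaker inhibitor. Within the data shown here, the one measured step, a 4.1-fold lower number from compound 1 to compound 2 (0.62 log units; beyond the scatter), is methyl in place of hydrogen on an oxygen on an aromatic ring.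

Compound 3 `Cc1cc(/C=C/c2ccc(O)c(O)c2)[nH]n1` has not yet been measured. It differs from compound 1 by hydroxy in place of hydrogen on an aromatic carbon, with the new hydroxy ortho to a hydroxy group and meta to a group of 8 heavy atoms.

Among the measured compounds shown here, the data hold no step of this same kind, so the methyl step bears on the change only loosely. Going by the modest size of a 4.1-fold lower number from compound 1 to compound 2 (0.62 log units; beyond the scatter), a modest move toward a lower number is expected in this assay, although a result within the scatter would be no surprise. The expected change is a 2.2-fold lower number from compound 1 to compound 3 (0.33 log units; beyond the scatter). For compound 3 the estimated value is 18000 nM, with an expected range from 5000 nM to 50000 nM.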

Compound 3, half-maximal inhibitory concentration: 41200 nM
For compound 3 the middle estimate is 2.3-fold (0.36 log units) below the measured one; measured number inside the range.
By their numbers in this assay, from the lowest: compound 2; then compounds 1 and 3 (each within the scatter of the next).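

In this assay, hydroxy in place of hydrogen on the aromatic carbon, ortho to a hydroxy group and meta to a group of 8 heavy atoms, gives a 1.1-fold higher number from compound 1 to compound 3 (0.03 log units; within the scatter), so this position takes the new hydroxy with no readable shift in the number. Among these compounds, this is the first view of a change on a ring carbon itself: the only earlier step, a 4.1-fold lower number from compound 1 to compound 2 (0.62 log units; beyond the scatter), altered the existing hydroxy at its oxygen and lay beyond the scatter, whereas this one lies within it. Nothing among the data shown explains why the added hydroxy leaves the number where it stands.

The compounds shown leave open whether this carbon is indifferent to substitution in general or only to hydroxy, since a single group there cannot separate the two, and an amine, a fluorine or a methyl at the same place would be needed to tell. They also leave open whether the same hydroxy would read the same way on the methoxy-bearing core of compound 2, where the ortho neighbour would no longer be a hydroxy group.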